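The source may report more compounds than this note shows. Statements on the series, on what has been measured and on what is new or still open speak of the compounds shown alone.

Measured so far in a functional assay on A549 cells (Homo sapiens) for inhibition, with a stated time of 72 h; a lower number here means a stronger inhibitor, a higher number a weaker inhibitor:
- compound 1 `Cc1ccc(C)c(NC(=O)Nc2nc(Sc3c[nH]c4ccccc34)cc(N3CCCCC3)n2)c1` gives 25400 nM
- compound 2 `Cc1ccc(C)c(NC(=O)Nc2nc(Sc3c[nH]c4ccccc34)cc(N3CCN(Cc4ccccc4)CC3)n2)c1` gives > 50000 nM, which is a limit and not a number
- compound 3 `Cc1ccc(NC(=O)Nc2nc(Nc3ccccc3)cc(Sc3c[nH]c4ccccc34)n2)cc1` gives 23500 nM

Among the measured compounds shown here, compound 1 and compound 3 lie within the usual scatter of each other, so compound 1 stands level with the only other exact number. The next compound, compound 4 `O=C(Nc1ccccc1)Nc1nc(Sc2c[nH]c3ccccc23)cc(N2CCCCC2)n1`, keeps the core of compound 1 and changes one group: phenyl in place of 2,5-dimethylphenyl on an amide-type nitrogen. For the measured compounds named here, no measured pair isolates this change, so the expectation starts from compound 1 at 25400 nM and assumes no shift beyond the scatter in this assay. The expected size of a 1.1-fold higher number from compound 1 to compound 4 (0.03 log units; within the scatter) is therefore small. For compound 4 the estimated value is 27000 nM, with an expected range from 12000 nM to 50000 nM.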

Compound 4, half-maximal inhibitory concentration: 33100 nM
Estimate against measurement, compound 4: 1.2-fold (0.09 log units) below; low and high end bracket the measured number.
By their numbers in this assay, from the lowest: compounds 3, 1 and 4 (each within the scatter of the next). At a limit, above all of these: compound 2.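

In this assay, among the compounds shown here, phenyl in place of 2,5-dimethylphenyl on an amide-type nitrogen gives a 1.3-fold higher number from compound 1 to compound 4 (0.11 log units; within the scatter) and so offers the first comparison here in which only one place changes. At this position, the two methyl groups of the ring make no readable difference to this read-out. The data shown give no reason for this result.

Going by these compounds, how far this position tolerates larger changes stays open. A pyridyl ring or a cyclohexyl group on this nitrogen, or a carboxylic acid on the phenyl ring, lies outside the compounds shown.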